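Two Pyridinyl Isomers, Two Cores, One Lyase Readout

The compounds below may be only part of what the source reports. "The series", "measured", "known", "first", "only" and "open" are said of these compounds alone.

Compound 1 `Fc1ccc(-c2ccc3c(-c4cccnc4)cccc3c2)cc1` gives 2% in an assay for inhibition of steroid 17-alpha-hydroxylase/17,20 lyase (Homo sapiens), tested at 0.2 uM (a higher number here means a stronger effect of the compound at the concentration tested, a lower number a weaker effect), and compound 2 `Fc1ccc(-c2ccc3c(-c4ccncc4)cccc3c2)cc1` gives 1%. The change between them is pyridin-4-yl in place of pyridin-3-yl on an aromatic carbon, and the step is a number 1 percentage points lower from compound 1 to compound 2 (within the scatter). Compound 3 `Oc1ccc2cc(-c3cccc(-c4cccnc4)c3)ccc2c1` has a core that differs from that of compound 1 in a way that is not broken down here. In this assay compound 3 gives 0%; its values and those of compounds 1 and 2 lie within the scatter of one another, so no order among the three is claimed.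

Compound 4 `Oc1ccc2cc(-c3cccc(-c4ccncc4)c3)ccc2c1` has not yet been measured. It differs from compound 3 by pyridin-4-yl in place of pyridin-3-yl on an aromatic carbon. This is the same kind of change as that from compound 1 to compound 2, though not the same: in compound 1 the place is part of a fused or bridged system of two rings, ortho to a fused ring and meta to a fused ring, whereas in compound 3 it is meta to a large group. Since the earlier step was a number 1 percentage points lower from compound 1 to compound 2 (within the scatter), the expected step is a number 1 percentage points higher from compound 3 to compound 4 (within the scatter). Compound 4 is therefore estimated at 1%, with a likely range from -5% to 8%.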

Compound 4, a percentage reported as inhibition, at one concentration (the size of the read-out at that concentration, not a potency): 31%
The estimate for compound 4 lay 30 percentage points below the measured number, and the stated range ends below it.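

The change from pyridin-3-yl to pyridin-4-yl did not carry over from one core to the other in this assay: the same change on two cores in this assay, a number 1 percentage points lower (within the scatter) from compound 1 to compound 2 and a number 31 percentage points higher (beyond the scatter) from compound 3 to compound 4, 32 percentage points apart, beyond the scatter of two such steps. On the core of compound 3, the swap alone gives a number 31 percentage points higher from compound 3 to compound 4 (beyond the scatter), so in this pair, where the place is meta to a large group, the identity of the pyridinyl isomer matters, while on the core of compound 1 the two isomers cannot be told apart. This does not show which feature of the two cores separates the outcomes, since they differ in more than one way, and two pairs give no rule for any further core.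

The compounds shown leave open whether the higher number of compound 4 holds when its hydroxyl group gives way to a methoxy group, an amine or a carboxylic acid. They also leave open how a pyridin-2-yl group would read on either core, and, with a single tested concentration, how potent compound 4 is.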